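Nitro in Place of Fluoro on a Shared Core

The compounds below may be only part of what the source reports. "The series", "measured", "known", "first", "only" and "open" are said of these compounds alone.

Compound 2 `O=C(/N=C/c1ccc(F)cc1)Nc1ccc2c(c1)C(=O)C(=O)N2CN1CCCCC1` stands in a functional assay on the whole organism (strain Swiss albino) with Mus musculus as the target, with a stated time of 4 h (on this read-out lower numbers stand for an effect already at smaller amounts and higher numbers for an effect only at larger amounts of compound), at 300 mg/kg, level with compound 1 `O=C(/N=C/c1ccccc1Cl)Nc1ccc2c(c1)C(=O)C(=O)N2CN1CCCCC1`, which gives 300 mg/kg. Among the compounds with values here, the only measured step, no change at the digits printed from compound 1 to compound 2 (within the scatter), shows that 4-fluorophenyl in place of 2-chlorophenyl on a carbon with a double bond to nitrogen left the read-out where it was. Compound 3 `O=C(/N=C/c1ccc([N+](=O)[O-])cc1)Nc1ccc2c(c1)C(=O)C(=O)N2CN1CCCCC1` carries the change (nitro in place of fluoro on an aromatic carbon). That single flat step is all that bears on it, and a nitro group has not been tested in this series, so no shift beyond the scatter is expected. The estimated step is no change at the digits printed from compound 2 to compound 3 (within the scatter), giving for compound 3 an expected 300 mg/kg within 100 mg/kg to 600 mg/kg.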

Compound 3, minimum effective dose: 100 mg/kg
The estimate for compound 3 lay 3.0-fold (0.48 log units) above the measured number; low and high end bracket the measured number.
By their numbers in this assay, from the lowest: compound 3; then compounds 1 and 2 (each within the scatter of the next).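

In this assay, nitro in place of fluoro on this aromatic carbon gives a 3.0-fold lower number from compound 2 to compound 3 (0.48 log units; beyond the scatter), and 4-nitrophenyl in place of 2-chlorophenyl gives a 3.0-fold lower number from compound 1 to compound 3 (0.48 log units; beyond the scatter). The flat step between the two earlier compounds had suggested that this ring tolerates change without effect, but the read-out does respond to the group placed here. Nothing measured here explains the shift. The compounds shown leave open whether an amine or a nitrile on the same carbon would also lower the number, or whether this is particular to nitro.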